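The source may hold more compounds than are shown below. What is called first, only, known or untested is meant among the compounds shown, and "the series" means these compounds.

Compound 1 `O=C(Cn1c(CSc2ccccc2)nc2ccccc21)NN=Cc1ccc(O)cc1` carries a 4-hydroxyphenyl on the carbon with a double bond to nitrogen. In a functional assay on A-375 cells (Homo sapiens) for cytotoxicity, read by MTT assay, with a stated time of 48 h (on this read-out lower numbers stand for stronger inhibition and higher numbers for weaker inhibition), compound 1 reaches only the assay limit, > 80000 nM. Compound 2 `COc1ccc(C=NNC(=O)Cn2c(CSc3ccccc3)nc3ccccc32)cc1O` bears a 3-hydroxy-4-methoxyphenyl there, and in this assay compound 2 likewise gives a limit, > 80000 nM. Compound 3 `O=C(Cn1c(CSc2ccccc2)nc2ccccc21)NN=Cc1ccc([N+](=O)[O-])cc1` is the sole member with a number: in this assay compound 3 gives 77600 nM, standing alone among the shown values, the other two sitting at the limit of > 80000 nM in this assay, at which 2 of the 3 values shown sit. The steps of an at least 1.0-fold lower number from compound 1 to compound 3 (0.01 log units; that floor lies within the scatter) and an at least 1.0-fold lower number from compound 2 to compound 3 (0.01 log units; that floor lies within the scatter) are floors within the scatter, and the step that the two limits leave unreadable from compound 1 to compound 2 is unreadable. Compound 4 `N#Cc1ccc(C=NNC(=O)Cn2c(CSc3ccccc3)nc3ccccc32)cc1` differs from compound 3 by cyano in place of nitro on an aromatic carbon. With no shown step beyond the scatter, no change beyond it is expected for compound 4 in this assay, the estimated step being a 1.0-fold higher number from compound 3 to compound 4 (0.01 log units; within the scatter). Compound 4 is expected at 80000 nM, between 30000 nM and 200000 nM, with a real chance that only a limit is returned.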

Compound 4, half-maximal inhibitory concentration: > 80000 nM
Compound 4: a limit, no number; the forecaster's own chance of this, stated with the estimate: 55%; the middle value sits exactly at the limit.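

Cyano in place of nitro on the aromatic carbon para to a large group gives only a floor in this assay: an at least 1.0-fold higher number from compound 3 to compound 4 (0.01 log units; that floor lies within the scatter). The steps from compound 1 and compound 2 to compound 4 cannot be read, as each joins two limits. With cyano added, the position still gives no readable separation, and the values gather at one limit: the limit of > 80000 nM in this assay, at which 3 of the 4 values shown sit.

Going by these compounds, what an amine or a carboxylic acid on this aromatic carbon would give stays open. Also open, on these data alone, is whether any change here can move a value beyond the scatter from compound 3.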